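A few compounds are considered here, and "the series" means these few. Any claim that something is new, unique, unknown or untested is made for them only; others in the source may bear on it.

Working notes on the series. Among the compounds with values here, in a functional assay on PC-3 cells (Homo sapiens) for inhibition, read by MTT assay, with a stated time of 72 h, tested at 10 uM (a higher number here means more inhibition of growth at the concentration tested, a lower number less inhibition of growth), compound 2 `O=C(/C=C/c1cc([N+](=O)[O-])ccc1Cl)/C=C/c1ccccc1Oc1ncnc2ccc(Cl)cc12` gives 86.9% and stands highest of the three numbers so far; compound 1 `O=C(/C=C/c1ccc(Cl)c([N+](=O)[O-])c1)/C=C/c1ccccc1Oc1ncnc2ccc(Cl)cc12` gives 62.5% and compound 3 `O=C(/C=C/c1ccc(Oc2ncnc3ccc(Cl)cc23)cc1)/C=C/c1ccc(Cl)c(Cl)c1` gives 33.5%. Within the data shown here, the only single-site step measured, a number 24.4 percentage points higher from compound 1 to compound 2 (beyond the scatter), shows that rearranging chloro and nitro on that aryl shifts growth inhibition beyond the scatter. Compound 4 `O=C(/C=C/c1ccccc1Oc1ncnc2ccc(Cl)cc12)/C=C/c1cccc(Cl)c1Cl` carries 2,3-dichlorophenyl in place of 2-chloro-5-nitrophenyl on a double-bonded chain carbon bound to a double-bonded chain carbon. Among the measured compounds shown here, no measured step covers this exact swap; compound 3, which holds a dichlorophenyl with the core attached differently, gives a far lower number, but that pair differs in two places. Given the sensitivity shown by the step from compound 1 to compound 2, a drop of a number 26.9 percentage points lower from compound 2 to compound 4 (beyond the scatter) is expected, and compound 4 is estimated at 60% (range 35% to 85%).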

Compound 4, percent growth inhibition at one concentration: 73.8%
The estimate for compound 4 lay 13.8 percentage points below the measured number; the range from low to high includes it.
By their numbers in this assay, from the lowest: compound 3; then compound 1; then compound 4; then compound 2.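

At this position, on a double-bonded chain carbon bound to a double-bonded chain carbon, an aryl group without nitro still gives substantial growth inhibition in this assay. Replacing the nitro-bearing aryl groups with 2,3-dichlorophenyl gives a number 13.1 percentage points lower from compound 2 to compound 4 (beyond the scatter), but also a number 11.3 percentage points higher from compound 1 to compound 4 (beyond the scatter), so the effect of this swap depends on which chloro-nitro arrangement it replaces. No evidence at hand accounts for this order.

On these data alone, it remains open whether an aryl group bearing an amine or a carboxylic acid would maintain growth inhibition at this position. The order of these aryl groups is also unresolved for the core attachment seen in compound 3.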